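A few compounds are considered here, and "the series" means these few. Any claim that something is new, unique, unknown or untested is made for them only; others in the source may bear on it.

Compound 1, `CCCCCCCCCCSc1ncnc2c1ncn2C1CCCC1O`: "not determined" (no result reported)
Compound 2, `CCCCCCCCCCCCOc1nc(N)nc2c1ncn2CC(=O)OCC`: > 10 ug/mL

The study measures an ADME assay on Vero cells (Chlorocebus sabaeus) for cytotoxicity; on this read-out lower numbers stand for higher toxicity in this test and higher numbers for lower toxicity in this test. Compound 1 stands nowhere on the numbers shown, since in this assay compound 1 gives "not determined" (no result reported). Compound 2 gives only a limit of the assay in this assay, > 10 ug/mL. For the measured compounds named here, the one value present thus rests on (the limit of > 10 ug/mL in this assay, at which 1 of the 2 values shown sits), and no step between two measured compounds is available.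

Compound 3, `CCCCCCCCCCSc1ncnc2c1ncn2CC(=O)OCC`, is not yet measured in this assay. It differs from compound 1 in one place: (ethoxycarbonyl)methyl in place of 2-hydroxycyclopentyl on an aromatic nitrogen. The group that enters is the same one carried by compound 2, which sits at the limit, while the decyl sulfanyl chain and the rest of the core of compound 1 remain. Going by the values given here, with no measured step, the size of the change from compound 1 to compound 3 in this assay cannot be drawn from the data; the expectation is a shift of no more than the usual scatter, in no set direction. Compound 3 is therefore expected to give about 20 ug/mL in this assay, within a range from 8 ug/mL to 60 ug/mL, most likely reported again as a limit.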

Compound 3, half-maximal cytotoxic concentration: > 62.5 ug/mL
Compound 3 ended at the assay's limit (the forecaster's own chance of this, stated with the estimate: 70%); middle value at least 3.1-fold (0.49 log units) from the limit.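

In this assay compound 3 gives > 62.5 ug/mL, which is a limit of the assay. For the compounds shown here, compound 1 offers no number to set against it, so no step from compound 1 to compound 3 can be read. The compounds shown leave open how far (ethoxycarbonyl)methyl in place of 2-hydroxycyclopentyl shifts cytotoxicity, or in which direction.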